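One Substitution, Tried on Two Related Cores

A few compounds are considered here, and "the series" means these few. Any claim that something is new, unique, unknown or untested is made for them only; others in the source may bear on it.

Compound 1 `COc1cc(-c2nc3ccc([N+](=O)[O-])cc3[nH]2)cc(-c2nc3ccc([N+](=O)[O-])cc3[nH]2)c1`: 17100 nM
Compound 2 `O=[N+]([O-])c1cc(-c2nc3ccc([N+](=O)[O-])cc3[nH]2)cc(-c2nc3ccc([N+](=O)[O-])cc3[nH]2)c1`: 1200 nM
Compound 3 `COc1cc(-c2nc3ccc(C(F)(F)F)cc3[nH]2)cc(-c2nc3ccc(C(F)(F)F)cc3[nH]2)c1`: 11900 nM

The three measured compounds were tested in a functional assay on MCF7 cells (Homo sapiens) for cytotoxicity, read by MTT assay, with a stated time of 48 h; on this read-out lower numbers stand for stronger inhibition and higher numbers for weaker inhibition. Compound 1 and compound 2 share one core and differ in a single place: nitro in place of methoxy on an aromatic carbon. That change produced a 14-fold lower number from compound 1 to compound 2 (1.15 log units; beyond the scatter), a step well beyond the usual scatter of this assay.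

Compound 3 carries a different core; the difference between the core of compound 3 and the core of compound 1 is not broken down here. In this assay compound 3 gives 11900 nM, which lies within the scatter of the value of compound 1, so the two cannot be ordered against each other. Compared with compound 2, compound 3 shows the clearly higher number.

Compound 4 `O=[N+]([O-])c1cc(-c2nc3ccc(C(F)(F)F)cc3[nH]2)cc(-c2nc3ccc(C(F)(F)F)cc3[nH]2)c1` is still to be measured. It stands to compound 3 exactly as compound 2 stands to compound 1: nitro in place of methoxy on an aromatic carbon. The surroundings of the changed position are described in the same words in both pairs, so this is the same change on a second core.

For the measured compounds named here, since the one earlier instance of this change, from compound 1 to compound 2, gave a large step, a step of similar size is expected here, and the estimate for the move is a 12-fold lower number from compound 3 to compound 4 (1.08 log units; beyond the scatter). On that basis compound 4 is expected to give about 1000 nM in this assay, most likely between 300 nM and 4000 nM.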

Compound 4, half-maximal inhibitory concentration: 9400 nM
For compound 4 the middle estimate is 9.4-fold (0.97 log units) below the measured one, and the stated range ends below it.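

On the core of compound 3, nitro in place of methoxy gave a 1.3-fold lower number from compound 3 to compound 4 (0.10 log units; within the scatter) in this assay and so that pair cannot be ordered, whereas the same change on the core of compound 1 gave a 14-fold lower number from compound 1 to compound 2 (1.15 log units; beyond the scatter) as a clear step. What this does not show is which feature of the two cores goes with the gap, or how a further core would respond, as two pairs give no rule for the series and cannot say which of them is the more typical. What it does show is that, in this assay, the size of the step seen on one core did not carry over to the other, so the step on one core is no safe guide to the step on the next: the same change on two cores in this assay, a 14-fold lower number (1.15 log units; beyond the scatter) from compound 1 to compound 2 and a 1.3-fold lower number (0.10 log units; within the scatter) from compound 3 to compound 4, 11-fold (1.05 log units) apart, beyond the scatter of two such steps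

The compounds shown leave open whether another group in the place of methoxy, such as an amine, a nitrile or a carboxylic acid, would give steps that differ between the two cores in the same way. They also leave open whether the gap between the two steps would appear again in any other cell line or at any other exposure time.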